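Removing a Methyl from the Aromatic Oxygen

A few compounds are considered here, and "the series" means these few. Any claim that something is new, unique, unknown or untested is made for them only; others in the source may bear on it.

Measured compounds:
- compound 1, `CC1=CC[C@@H]([C@@](C)(O)CCCC(C)(C)NC(=S)NN)CC1`, gives 15300 nM in a functional assay on MCF7 cells (Homo sapiens) for cytotoxicity, read by sulforhodamine B assay; on this read-out higher numbers stand for weaker inhibition of growth and lower numbers for stronger inhibition of growth
- compound 2, `CC1=CC[C@@H]([C@@](C)(O)CCCC(C)(C)NC(=S)N/N=C\c2ccccc2)CC1`, gives 7720 nM in this assay
- compound 3, `COc1ccc(/C=N\NC(=S)NC(C)(C)CCC[C@](C)(O)[C@@H]2CC=C(C)CC2)cc1`, gives 6500 nM in this assay

Among these three, compound 3 gives the lowest number in this assay; one of the two steps ending at it, a 1.2-fold lower number from compound 2 to compound 3 (0.07 log units; within the scatter), does not separate the two compounds it joins, whereas the other, a 2.4-fold lower number from compound 1 to compound 3 (0.37 log units; beyond the scatter), is a modest step beyond the scatter. Compound 4, `CC1=CC[C@@H]([C@@](C)(O)CCCC(C)(C)NC(=S)N/N=C\c2ccc(O)cc2)CC1`, has not yet been measured. It differs from compound 3 only in one spot: hydrogen in place of methyl on an oxygen on an aromatic ring.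

Going by the values given here, the one measured step that touches this part of the molecule is a 1.2-fold lower number from compound 2 to compound 3 (0.07 log units; within the scatter), where adding the methoxy group changed nothing beyond the scatter. The step of a 2.0-fold lower number from compound 1 to compound 2 (0.30 log units; within the scatter), attaching the aromatic group, was also within the scatter. Since the aromatic substituent had little effect so far, trimming the methyl from its oxygen is expected to leave the number roughly where compound 3 sits, with a step of a 1.0-fold higher number from compound 3 to compound 4 (0.02 log units; within the scatter) that is expected to stay within the scatter. Compound 4 is therefore estimated at 6800 nM, with a range from 3000 nM to 15000 nM.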

Compound 4, concentration for 50% growth inhibition: 6230 nM
Beside the measured number, compound 4's estimate is 1.1-fold (0.04 log units) above it; the range from low to high includes it.
By their numbers in this assay, from the lowest: compounds 4, 3, 2 and 1 (each within the scatter of the next, the first and the last beyond it).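

In this assay the methyl on the aromatic oxygen can be removed with no change beyond the scatter (a 1.0-fold lower number from compound 3 to compound 4 (0.02 log units; within the scatter)), and adding hydroxy in place of hydrogen on the aromatic carbon also stays within it (a 1.2-fold lower number from compound 2 to compound 4 (0.09 log units; within the scatter)), so hydrogen, methoxy and hydroxy at this spot are not separated from one another. Only the larger change that brings in the whole 4-hydroxyphenyl-bearing group goes beyond the scatter, and that step is modest (a 2.5-fold lower number from compound 1 to compound 4 (0.39 log units; beyond the scatter)). No measurement at hand explains why these groups read alike.

As far as these compounds go, whether a group of another kind here, such as an amine or a carboxylic acid, would read differently remains open. So does the effect of a longer chain on this oxygen, such as propoxy in place of methoxy.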